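The source may hold more compounds than are shown below. What is called first, only, known or untested is meant among the compounds shown, and "the series" means these compounds.

Working notes on a short series in a functional assay on MCF7 cells (Homo sapiens) for cytotoxicity, read by MTT assay, with a stated time of 72 h (on this read-out lower numbers stand for higher toxicity in this test and higher numbers for lower toxicity in this test), read by the concentration lethal to half the cells. Compound 1 `COc1ccc(CNc2nc(SC)nc3ncccc23)cc1` gives in this assay only a limit, > 100000 nM, not a number. Compound 2 `[SeH]c1nc(NCc2ccccc2)c2ccccc2n1` likewise gives in this assay a limit, > 100000 nM. Compound 3 `Nc1nc([SeH])nc2ncccc12` gives in this assay a limit as well, > 100000 nM, again no number. Among the measured compounds shown here, every value shown is such a limit, (the limit of > 100000 nM in this assay, at which 3 of the 3 values shown sit); compound 3 therefore stands nowhere apart from compounds 1 and 2, and no step between measured compounds can be sized.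

Compound 4 `[SeH]c1nc([SeH])c2cccnc2n1` differs from compound 3 in one selenium atom in place of one nitrogen atom, on an aromatic carbon, in words one selenium atom in place of one nitrogen atom, on an aromatic carbon. For the measured compounds named here, no measured pair gives the size of such a change. With all three measured compounds sitting at the limit, the expectation for compound 4 in this assay is a value not beyond the scatter from that limit, so a number no higher from compound 3 to compound 4 (the limit leaves the size open) is expected. The estimate for compound 4 is 100000 nM, range 30000 nM to 300000 nM, most likely reported again as a limit.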

Compound 4, concentration lethal to 50% of the cells: 82700 nM
The estimate for compound 4 lay 1.2-fold (0.08 log units) above the measured number; low and high end bracket the measured number.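

Among the compounds shown here, compound 4 is the first compound to give a number rather than a limit in this assay, so this position, on an aromatic carbon opposite the ring nitrogen, now has one readable result for a selenium atom in place of the amino nitrogen. Compound 3 holds only a limit, so the change is known only as a floor: an at least 1.2-fold lower number from compound 3 to compound 4 (0.08 log units; that floor lies within the scatter). That floor does not separate the two compounds, and most of the series still sits at one limit: the limit of > 100000 nM in this assay, at which 3 of the 4 values shown sit.

As far as these compounds go, the true size of the step stays open, with no number for compound 3 to set against it. Also open, from the compounds shown here alone, is whether another group at this position, such as a carboxylic acid or a chlorine atom, would give a number in this assay at all.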